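Swapping the side chain on a strained bicyclic core

This account rests on a few compounds, and the source may have more. Where it says the series, first, only, none or still open, it means among the compounds named here.

Compound 1 `C[C@H](O)[C@H]1C(=O)N2C(C(=O)O)=C(C(C)(C)C)O[C@H]12` is measured in an ADME assay, in phosphate buffer, at 28 degrees C, at pH 7.0 (on this read-out lower numbers stand for a shorter-lived compound and higher numbers for a longer-lived compound), where compound 1 gives 7.1 h, the lowest of the two numbers seen. Compound 2 `CC(C)(C)C1=C(C(=O)O)N2C(=O)[C@H]([C@@H](O)CCc3ccc(O)cc3)[C@H]2O1` gives 21.2 h in this assay. Among the measured compounds shown here, the one measured step, a 3.0-fold higher number from compound 1 to compound 2 (0.48 log units; beyond the scatter), is a modest rise. Compound 3 `CC(C)(C)C1=C(C(=O)O)N2C(=O)[C@H](CNS(C)(=O)=O)[C@H]2O1` changes a different part of that side chain: (methanesulfonamido)methyl in place of 1-hydroxyethyl on a saturated ring carbon. For the measured compounds named here, no measured step follows this change, so the step from compound 1 to compound 2 offers only a loose guide. The step of a 1.1-fold higher number from compound 1 to compound 3 (0.05 log units; within the scatter) is expected to stay small. Compound 3 is estimated at 8 h in this assay, within 3 h to 22 h.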

Compound 3, half-life: 2.2 h
For compound 3 the middle estimate is 3.6-fold (0.56 log units) above the measured one; measured number below the stated range.
By their numbers in this assay, from the lowest: compound 3; then compound 1; then compound 2.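

Replacing 1-hydroxyethyl with (methanesulfonamido)methyl gives a 3.2-fold lower number from compound 1 to compound 3 (0.51 log units; beyond the scatter) in this assay and so moves the number the opposite way to a 3.0-fold higher number from compound 1 to compound 2 (0.48 log units; beyond the scatter) at the same saturated ring carbon. Changing this side chain can therefore shorten the half-life as well as lengthen it, with the rest of the molecule unchanged.

From the compounds shown here alone, it remains open whether a plain aminomethyl group at this carbon, without the methanesulfonyl part, would give a shorter or longer half-life than compound 1. Nothing available here explains the direction of either step.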